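Swapping the furan for a methylpyridine on the sulfonyl group

The compounds below may be only part of what the source reports. "The series", "measured", "known", "first", "only" and "open" are said of these compounds alone.

Among the compounds with values here, compound 1 `CNCc1cn(S(=O)(=O)c2ccoc2)c(-c2cccnc2F)c1F` is the only compound with a number: in a functional assay on the whole organism (strain Jcl:Sprague-Dawley) for inhibition, with Rattus norvegicus as the target, with stated times of 3 min and 3 h, at a dose of 1 mg/kg by the intravenous route (a lower number here means less inhibition, a higher number more inhibition at the dose given (going by the name of the read-out)), compound 1 gives 95%. Compound 2 `CNCc1cn(S(=O)(=O)c2cccnc2Cl)c(-c2cccnc2F)c1F` carries no number; in this assay compound 2 is reported as "not determined" (no result reported). Compound 3 `CNCc1cn(S(=O)(=O)c2cncc(C)c2)c(-c2cccnc2F)c1F` differs from compound 1 by 5-methylpyridin-3-yl in place of furan-3-yl on a sulfonyl sulfur. Within the data shown here, no measured pair shares this change, so the size of the step is open. Because compound 1 gives 95% the room upward is small, and the expected step is a number 7 percentage points lower from compound 1 to compound 3 (within the scatter). Compound 3 is therefore expected to give 88%, within 60% to 98%.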

Compound 3, a percentage reported as inhibition, in the whole organism at one dose (the size of the read-out at that dose, not a potency): 87%
Beside the measured number, compound 3's estimate is 1 percentage points above it; the measured number falls inside the stated range.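

In this assay, 5-methylpyridin-3-yl in place of furan-3-yl on the sulfonyl sulfur gives a number 8 percentage points lower from compound 1 to compound 3 (within the scatter). This position therefore accepts a six-membered aromatic ring bearing a methyl group as well as a five-membered one, with no change beyond the usual scatter at this single dose. No available evidence bears on this result.

The compounds shown leave open what an amine or a carboxylic acid on that ring would do. They also leave open whether compound 1 and compound 3 differ at other doses.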